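Shortening an Ethyl Chain on a Cell-Growth Inhibitor

A few compounds are considered here, and "the series" means these few. Any claim that something is new, unique, unknown or untested is made for them only; others in the source may bear on it.

Compound 1 `C=C(Br)C(=O)Nc1cccc(-c2cn3nc(-c4ccc(CC)cc4)sc3n2)c1` has been examined in a functional assay on CCRF-CEM cells (Homo sapiens) for inhibition, read by cell counting, with a stated time of 3 days (a higher number here means a weaker inhibitor, a lower number a stronger inhibitor), where compound 1 gives 3400 nM. Within the data shown here, the only other compound measured there, compound 2 `Nc1cccc(-c2cn3nc(Cc4ccc(Cl)cc4)sc3n2)c1`, gives 42000 nM in this assay. Compound 1 therefore holds the lowest of the two numbers, and the gap to compound 2 lies beyond the scatter of repeated runs. Compound 3 `C=C(Br)C(=O)Nc1cccc(-c2cn3nc(-c4ccc(C)cc4)sc3n2)c1` is built from compound 1 by a single change, hydrogen in place of methyl on a saturated chain carbon bound to an aromatic carbon, which reads one bond further out as ethyl to methyl, 4-ethylphenyl to 4-methylphenyl. Among the measured compounds shown here, no measured pair shows this change, so its effect in this assay cannot be read from the data; the step from compound 1 to compound 3 is expected to be small, with no direction that clears the scatter. On that basis compound 3 is estimated at 4000 nM, between 1500 nM and 11000 nM, a move of a 1.2-fold higher number from compound 1 to compound 3 (0.07 log units; within the scatter) that is expected to remain within ordinary variation.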

Compound 3, half-maximal inhibitory concentration: 1700 nM
Compound 3: middle estimate off by 2.4-fold (0.37 log units), on the high side, and the stated range covers the measured number.
By their numbers in this assay, from the lowest: compounds 3 and 1 (each within the scatter of the next); then compound 2.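

Going from 4-ethylphenyl to 4-methylphenyl in this assay gives a 2.0-fold lower number from compound 1 to compound 3 (0.30 log units; within the scatter), the only reading of a single change in this series, since compound 2 differs from compound 1 in more than one place. At this position, then, the chain can lose its methyl with no difference that can be told from ordinary variation between repeated runs. Nothing measured here gives a reason for the size of this step or a property of either group.

What the compounds shown leave open is how far this tolerance reaches: a longer chain such as propyl or butyl at the same place might behave differently. So might a plain phenyl with hydrogen in place of the whole chain, or an amine or a carboxylic acid there.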